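Fluoro for Methyl on the Sulfonamide Ring of Cinnamoyl Sulfonamides

The source may hold more compounds than are shown below. What is called first, only, known or untested is meant among the compounds shown, and "the series" means these compounds.

The measured compounds are:
Compound 1, `Cc1ccc(S(=O)(=O)NC(=O)/C=C/c2ccc(Br)cc2)cc1`, 12.1 ug/mL
Compound 2, `O=C(/C=C/c1ccc(Br)cc1)NS(=O)(=O)c1ccc(F)cc1`, 1.2 ug/mL
Compound 3, `Cc1ccc(S(=O)(=O)NC(=O)/C=C/c2ccccc2[N+](=O)[O-])cc1`, 10.3 ug/mL

All three were tested in a functional assay on B16-F10 cells (Mus musculus) for antiproliferative activity, read by ELISA and MTT assay, with a stated time of 48 h; on this read-out higher numbers stand for weaker inhibition and lower numbers for stronger inhibition. Compound 1 gives 12.1 ug/mL, and compound 2 gives 1.2 ug/mL. The two differ in one place, (fluoro in place of methyl on an aromatic carbon), and this change brought a 10-fold lower number from compound 1 to compound 2 (1.00 log units; beyond the scatter). Compound 3, which in this assay gives 10.3 ug/mL, carries a different core from compound 1; how the two cores differ is not broken down here. Its value sits close to that of compound 1, within the usual scatter, and well away from that of compound 2.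

Compound 4, `O=C(/C=C/c1ccccc1[N+](=O)[O-])NS(=O)(=O)c1ccc(F)cc1`, has not yet been measured. It differs from compound 3 by fluoro in place of methyl on an aromatic carbon. The place of the change reads the same, word for word, as for the pair of compound 1 and compound 2, so it is the same change made on the other core. Going by the values given here, whether the second core carries the change as well is unknown; the only guide is the step already seen. On that basis compound 4 is expected to show a 7.9-fold lower number from compound 3 to compound 4 (0.90 log units; beyond the scatter), resting on the step seen because of a 10-fold lower number from compound 1 to compound 2 (1.00 log units; beyond the scatter), with a wide range to allow for the core being different. The estimate for compound 4 in this assay is 1.3 ug/mL, with a likely range from 0.4 ug/mL to 4.5 ug/mL.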

Compound 4, half-maximal inhibitory concentration: 6 ug/mL
Beside the measured number, compound 4's estimate is 4.6-fold (0.66 log units) below it, outside the stated range (above it).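

In this assay, going from 4-methylphenyl to 4-fluorophenyl on the second core brought a 1.7-fold lower number from compound 3 to compound 4 (0.23 log units; within the scatter), so on this core the effect of the change cannot be told apart from the usual variation between repeated measurements. Set beside the step on the first core, the same change did not carry over at the same size: the same change on two cores in this assay, a 10-fold lower number (1.00 log units; beyond the scatter) from compound 1 to compound 2 and a 1.7-fold lower number (0.23 log units; within the scatter) from compound 3 to compound 4, 5.9-fold (0.77 log units) apart, beyond the scatter of two such steps This shows that the large drop seen on the core of compound 1 cannot be assumed for every core in this series, but with only one pair on each core it does not show which difference between the cores lies behind the gap, nor how the change would behave on any further core.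

Going by these compounds, it stays open whether a chloro, methoxy or trifluoromethyl group in place of the methyl would also separate the two cores, or whether this gap is particular to fluoro. On these data alone, it also stays open how the same change would behave on a core carrying neither the bromo nor the nitro group, for example one bearing an amine or a carboxylic acid instead.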